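The source may report more compounds than this note shows. Statements on the series, on what has been measured and on what is new or still open speak of the compounds shown alone.

Compound 3 `COC(=O)/C=C/c1cccc(N(Cc2ccc(-c3cccc(Cl)c3)cc2)C(=O)C(C)C)c1` gives 77 nM in an assay on isolated protein with Bile acid receptor (Homo sapiens) as the target (on this read-out lower numbers stand for an effect already at smaller amounts and higher numbers for an effect only at larger amounts of compound), the lowest of the three numbers, though its gap to compound 1 is within the scatter. Compound 1 `COC(=O)/C=C/c1cccc(N(Cc2ccc(/C=C/c3c(F)cccc3F)cc2)C(=O)C(C)C)c1` gives 108 nM in this assay, and compound 2 `COC(=O)/C=C/c1cccc(N(Cc2ccc(/C=C/c3ccccn3)cc2)C(=O)C(C)C)c1` gives 310 nM. The step of a 1.4-fold lower number from compound 1 to compound 3 (0.15 log units; within the scatter) lies within the scatter, while a 4.0-fold lower number from compound 2 to compound 3 (0.60 log units; beyond the scatter) and a 2.9-fold higher number from compound 1 to compound 2 (0.46 log units; beyond the scatter) lie beyond it. Compound 4 `COC(=O)/C=C/c1cccc(N(Cc2ccc(-c3cc(Cl)ccc3OC)cc2)C(=O)C(C)C)c1` differs from compound 3 by methoxy in place of hydrogen on an aromatic carbon, which cut one bond further out reads 3-chlorophenyl to 5-chloro-2-methoxyphenyl, the new group sitting ortho to a large group and para to a chloro group. Within the data shown here, no measured step adds a methoxy group or any substituent of this kind; the two steps that reach compound 3 only exchange the whole group on that aromatic carbon, and they range from within the scatter to modest. There is thus no direct guide for this change, and a number close to that of compound 3 is expected, with a wide range either way. Compound 4 is therefore estimated at 77 nM, between 30 nM and 220 nM, which corresponds to an expected step of no change at the digits printed from compound 3 to compound 4 (within the scatter).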

Compound 4, half-maximal effective concentration: 226 nM
Compound 4: middle estimate off by 2.9-fold (0.47 log units), on the low side; measured number outside the range, above it.
By their numbers in this assay, from the lowest: compounds 3 and 1 (each within the scatter of the next); then compounds 4 and 2 (each within the scatter of the next).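

In this assay, a group added to the 3-chlorophenyl ring proves able to move the number: methoxy in place of hydrogen, ortho to a large group and para to a chloro group, gives a modest step beyond the scatter (a 2.9-fold higher number from compound 3 to compound 4 (0.47 log units; beyond the scatter)). The resulting 5-chloro-2-methoxyphenyl group no longer matches the 2-(2,6-difluorophenyl)ethenyl group (a 2.1-fold higher number from compound 1 to compound 4 (0.32 log units; beyond the scatter)), whereas its step from the 2-(pyridin-2-yl)ethenyl group stays within the scatter (a 1.4-fold lower number from compound 2 to compound 4 (0.14 log units; within the scatter)). No measurement given here accounts for the effect of the methoxy group.

The compounds shown leave open whether a methyl, hydroxyl or ethoxy group on the same aromatic carbon would give a similar step. They also leave open whether methoxy would give this step without the chloro group.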